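Working notes: 2-hydroxyethyl in place of 4-methylphenyl

The compounds below may be only part of what the source reports. "The series", "measured", "known", "first", "only" and "open" are said of these compounds alone.

- compound 1 `COc1ccccc1-c1cn(C[C@H](O)[C@H]2OC(=O)C(OCc3ccccc3)=C2OCc2ccccc2)nn1`: > 100000 nM (a limit of the assay, not a number)
- compound 2 `O=C1O[C@H]([C@@H](O)Cn2cc(C3CC3)nn2)C(OCc2ccccc2)=C1OCc1ccccc1`: 38100 nM
- compound 3 `Cc1ccc(-c2cn(C[C@H](O)[C@H]3OC(=O)C(OCc4ccccc4)=C3OCc3ccccc3)nn2)cc1`: 8770 nM

In a functional assay on HepG2 cells (Homo sapiens) for antiproliferative activity, read by MTT assay, with a stated time of 72 h (a higher number here means a weaker inhibitor, a lower number a stronger inhibitor), compound 3 holds the lowest of the numbers, at 8770 nM. Compound 4 `O=C1O[C@H]([C@@H](O)Cn2cc(CCO)nn2)C(OCc2ccccc2)=C1OCc1ccccc1` carries 2-hydroxyethyl in place of 4-methylphenyl on an aromatic carbon. The closest measured precedent, also a non-aromatic group at this place, is cyclopropyl to 4-methylphenyl, a 4.3-fold lower number from compound 2 to compound 3 (0.64 log units; beyond the scatter). An aromatic group alone does not secure a low number: compound 1 goes against that pattern, with an at least 2.6-fold lower number from compound 1 to compound 2 (0.41 log units; beyond the scatter) and an at least 11-fold lower number from compound 1 to compound 3 (1.05 log units; beyond the scatter). A modest step to a higher number is therefore expected in this assay. The expected step is a 5.1-fold higher number from compound 3 to compound 4 (0.71 log units; beyond the scatter). For compound 4 the estimated value is 45000 nM, with an expected range of 15000 nM to 100000 nM.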

Compound 4, half-maximal inhibitory concentration: 68100 nM
Beside the measured number, compound 4's estimate is 1.5-fold (0.18 log units) below it; low and high end bracket the measured number.
By their numbers in this assay, from the lowest: compound 3; then compounds 2 and 4 (each within the scatter of the next). At a limit, above all of these: compound 1.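

In this assay, 2-hydroxyethyl does not hold the level of 4-methylphenyl on this aromatic carbon, a 7.8-fold higher number from compound 3 to compound 4 (0.89 log units; beyond the scatter), while against cyclopropyl, the other non-aromatic group, it shows a 1.8-fold higher number from compound 2 to compound 4 (0.25 log units; within the scatter), so these two non-aromatic groups are not separated. Against 2-methoxyphenyl the comparison gives an at least 1.4-fold lower number from compound 1 to compound 4 (0.16 log units; that floor lies within the scatter). The value of compound 1 is a limit of the assay, not a number: the limit of > 100000 nM in this assay, at which 1 of the 4 values shown sits.

Open, going by these compounds, is whether a longer chain or an amine in place of 2-hydroxyethyl would separate from cyclopropyl. Also open, on these data alone, is whether 4-chlorophenyl would keep the number of compound 3.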